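Working notes: from compound 3 to compound 4

A few compounds are considered here, and "the series" means these few. Any claim that something is new, unique, unknown or untested is made for them only; others in the source may bear on it.

Measured so far:
Compound 1 `COc1cc(N(Cc2nc3ccccc3[nH]2)S(=O)(=O)c2ccc(C)cc2)cc(OC)c1OC`: 3340 nM in a functional assay on PC-3 cells (Homo sapiens) for inhibition, read by MTT assay, with a stated time of 48 h; a lower number here means a stronger inhibitor, a higher number a weaker inhibitor
Compound 2 `COc1cc(N(Cc2nc3ccccc3[nH]2)S(=O)(=O)c2ccc(F)cc2)cc(OC)c1OC`: 7990 nM
Compound 3 `COc1cc(N(Cc2nc3ccccc3[nH]2)C(=O)c2ccccc2)cc(OC)c1OC`: > 50000 nM

Compound 3 stands apart from the other two. Its result in this assay is a limit of the assay and not a number; it sits at the limit of > 50000 nM in this assay, at which 1 of the 3 values shown sits. Both steps that reach it are beyond the scatter: an at least 14-fold higher number from compound 1 to compound 3 (1.17 log units; beyond the scatter) and an at least 6.2-fold higher number from compound 2 to compound 3 (0.79 log units; beyond the scatter). The benzoyl member is therefore the weakest of the three measured compounds.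

Compound 4 `COc1cc(N(Cc2nc3ccccc3[nH]2)C(=O)c2ccc(F)cc2)cc(OC)c1OC` keeps the benzoyl core of compound 3 and differs from it in one place: fluoro in place of hydrogen on an aromatic carbon. Going by the values given here, no measured step swaps hydrogen for fluoro. The closest measured step is a 2.4-fold higher number from compound 1 to compound 2 (0.38 log units; beyond the scatter), where fluoro replaced methyl on the aryl of the sulfonyl; that step was modest and toward a higher number. Among the compounds with values here, nothing among the measured compounds points to a fluoro on the aryl ring giving a lower number, and compound 3 already sits at the limit.

Compound 4 is therefore expected to give 80000 nM in this assay, with a range from 30000 nM to 300000 nM, most probably again as a limit. The implied step that the limit leaves unreadable from compound 3 to compound 4 is estimated to lie within the scatter.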

Compound 4, half-maximal inhibitory concentration: 21900 nM
Compound 4: middle estimate off by 3.7-fold (0.56 log units), on the high side, outside the stated range (below it).
By their numbers in this assay, from the lowest: compound 1; then compound 2; then compound 4. At a limit, above all of these: compound 3.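

Fluoro in place of hydrogen on an aromatic carbon, para to a large group, gives an at least 2.2-fold lower number from compound 3 to compound 4 (0.35 log units; beyond the scatter), which shows that a fluoro at this place on the benzoyl can lower the number; the one earlier fluoro step, in place of methyl on the sulfonyl side, went toward a higher number. The result of compound 3 is a limit of the assay and not a number, so this step has a minimum size only: the limit of > 50000 nM in this assay, at which 1 of the 4 values shown sits. Going by these compounds alone, compound 4 also gives the first readable comparison of carbonyl with sulfonyl, and both sulfonyl members remain the stronger ones (with a 2.7-fold higher number from compound 2 to compound 4 (0.44 log units; beyond the scatter) and a 6.6-fold higher number from compound 1 to compound 4 (0.82 log units; beyond the scatter)).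

From the compounds shown here alone, whether the lower number belongs to fluoro in particular stays open, as does the true size of the step, and a methyl, a chloro or an amine at the same place on the benzoyl would test the first point. The phenylsulfonyl member without a substituent, set against the 4-fluorophenyl sulfonyl of compound 2, would show whether hydrogen to fluoro acts in the same direction on the sulfonyl side.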